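Cytotoxicity notes on a benzimidazole-urea and amide series

The source may report more compounds than this note shows. Statements on the series, on what has been measured and on what is new or still open speak of the compounds shown alone.

Going by the values given here, compound 1 `CCN(CC)c1cc2[nH]c(C3CCCCC3)nc2cc1NC(=O)NCc1ccccc1` is the one member of the set with a result in an ADME assay on Vero cells (Chlorocebus sabaeus) for cytotoxicity, read by resazurin assay, with a stated time of 3 days; on this read-out lower numbers stand for stronger inhibition and higher numbers for weaker inhibition. In this assay compound 1 gives > 100 ug/mL, which is a limit of the assay and not a number. Compound 2 `CCCc1ccc(C(=O)Nc2cc3nc(C4CCCCC4)[nH]c3cc2N(CC)CC)cc1` has no result in this assay, recorded as "not determined" (no result reported). Compound 3 `CCN(CC)c1cc2[nH]c(C3CCCCC3)nc2cc1NC(=O)c1ccc(N(C)C)cc1` likewise has no result in this assay, recorded as "not determined" (no result reported), so compound 3 cannot be placed against the others by a number. Of the three entries shown, one sits at the limit of the assay and one more is without a value, as stated by the limit of > 100 ug/mL in this assay, at which 1 of the 3 values shown sits.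

Compound 4 `CCCOCC(=O)Nc1cc2nc(C3CCCCC3)[nH]c2cc1N(CC)CC` is not yet measured in this assay. It differs from compound 3 by propoxymethyl in place of 4-(dimethylamino)phenyl on a carbonyl carbon. Among the compounds with values here, no measured step between compounds of this set exists in this assay, so the size and direction of the change from compound 3 to compound 4 cannot be read from data; with compound 1 reaching only the limit (the limit of > 100 ug/mL in this assay, at which 1 of the 3 values shown sits), no step beyond the scatter is expected, and a limit again is the likelier outcome.

For compound 4 the expected value in this assay is 100 ug/mL, estimated between 40 ug/mL and 250 ug/mL.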

Compound 4, half-maximal inhibitory concentration: > 100 ug/mL
Compound 4: a limit, no number (the forecaster's own chance of this, stated with the estimate: 65%); the middle value lies on the limit itself.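

In this assay compound 4 gives > 100 ug/mL, which is a limit of the assay and not a number. Compound 1 also stands at a limit, so no step from compound 1 to compound 4 can be read: the limit of > 100 ug/mL in this assay, at which 2 of the 4 values shown sit.

The compounds shown leave open whether any real difference lies behind these two limits, and where compound 2 and compound 3 stand in this assay.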